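The compounds below may be only part of what the source reports. "The series", "measured", "known", "first", "only" and "open" are said of these compounds alone.

Measured compounds in a functional assay on KARPAS-422 cells (Homo sapiens) for antiproliferative activity, read by resazurin assay, with a stated time of 72 h; on this read-out lower numbers stand for stronger inhibition and higher numbers for weaker inhibition: compound 1 `Cc1cc(C)c(CN2CCc3c(Cl)cc([C@@H](CO)[C@@H]4CCOC4)c(Cl)c3C2=O)c(=O)[nH]1` gives 3950 nM; compound 2 `COc1cc(C)[nH]c(=O)c1CN1CCc2c(Cl)cc([C@@H](O)C3COC3)c(Cl)c2C1=O` gives 10600 nM; compound 3 `COC(c1cc(Cl)c2c(c1Cl)C(=O)N(Cc1c(C)cc(C)[nH]c1=O)CC2)C1CCOC1` gives 175 nM; 406 nM; 50 nM; 25 nM (4 entries).

Compound 2 stands at the highest of the two single numbers in this assay; the nearest is compound 1, whose lower number lies beyond the usual scatter, while compound 3 appears only through several entries that spread widely, as the several entries of compound 3 in this assay, 175 nM; 406 nM; 50 nM; 25 nM (4 entries) shows, and so yields no single number to rank against.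

Compound 4 `COc1cc(C)[nH]c(=O)c1CN1CCc2c(Cl)cc(-c3c(C)noc3C)c(Cl)c2C1=O` has not yet been measured in this assay. It differs from compound 2 in one place: a group of 7 heavy atoms (5 carbon, 1 nitrogen, 1 oxygen; one five-membered aromatic ring with 2 hetero atoms) in place of a group of 6 heavy atoms (4 carbon, 2 oxygen; one four-membered non-aromatic ring with 1 hetero atom), on an aromatic carbon The 3,5-dimethyl-1,2-oxazol-4-yl group takes the position ortho to a chloro group and meta to the other chloro group on the carbon-only six-membered aromatic ring of the shared core, and the hydrogen-bond donor of compound 2 is lost with the leaving group.

For the measured compounds named here, no measured pair tracks this particular change, so the expectation rests on where compound 2 stands and on the spread seen among compounds 1 and 3. The step from compound 2 to compound 4 in this assay is expected to lower the number moderately, a 5.3-fold lower number from compound 2 to compound 4 (0.72 log units; beyond the scatter), though a change within the scatter cannot be excluded.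

Compound 4 is therefore estimated at 2000 nM, with a plausible range from 400 nM to 9000 nM.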

Compound 4, half-maximal inhibitory concentration in the KARPAS-422 assay: 27 nM
Estimate against measurement, compound 4: 74-fold (1.87 log units) above; the whole stated range lies above it.
By their numbers in the KARPAS-422 assay, from the lowest: compound 4; then compound 1; then compound 2.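

Compounds 1, 2 and 3 all carry a non-aromatic ring within the side group on this aromatic carbon, so none of them showed how the KARPAS-422 read-out responds when an aromatic ring is attached there directly. Placing the 3,5-dimethyl-1,2-oxazol-4-yl group on this carbon, ortho to one chloro group and meta to the other, gives a large change in the KARPAS-422 assay, with a 390-fold lower number from compound 2 to compound 4 (2.59 log units; beyond the scatter), and the hydrogen-bond donor of the leaving group is not needed for a low number here. The same replacement also shifts a second read-out: in a physicochemical assay for lipophilicity, at pH 7.4 (on this read-out higher numbers stand for higher lipophilicity and lower numbers for lower lipophilicity), compound 2 gives 1.3 and compound 4 gives 2.7, so the two shifts arrive together in this one pair.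

This single pair cannot separate the loss of the hydroxyl group from the arrival of the aromatic ring, nor show whether the shift in distribution coefficient has any bearing on the antiproliferative result. Also open, as far as these compounds go, is how this carbon would respond to an unsubstituted 1,2-oxazol-4-yl group, which would test the two methyl groups, or to a primary amine or a carboxylic acid.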